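Methoxy on the pendant phenyl of the triazole ether

The compounds below may be only part of what the source reports. "The series", "measured", "known", "first", "only" and "open" are said of these compounds alone.

Measured so far:
compound 1 `CCOC(=O)C1=Cc2ccccc2OC1(OCc1cn(-c2ccccc2)nn1)C(F)(F)F`: > 150000 nM
compound 2 `CCOC(=O)C1=Cc2ccccc2OC1(OCc1cc(-c2ccc(C)cc2)no1)C(F)(F)F`: > 150000 nM
compound 3 `CCOC(=O)C1=Cc2ccccc2OC1(OCc1cc(-c2ccc(F)cc2)no1)C(F)(F)F`: 42300 nM

In a functional assay on HeLa cells (Homo sapiens) for inhibition, read by MTT assay, with a stated time of 24 h (on this read-out lower numbers stand for stronger inhibition and higher numbers for weaker inhibition), compound 1 gives > 150000 nM, a limit of the assay and not a number. Compound 2 likewise gives > 150000 nM, again a limit. Within the data shown here, compound 3 gives 42300 nM, the only numerical value in the set. Among the measured compounds shown here, the one step measured between neighbours is an at least 3.5-fold lower number from compound 2 to compound 3 (0.54 log units; beyond the scatter), a fluoro in place of methyl on the aromatic carbon of the pendant phenyl. Most of the set rests at the limit of > 150000 nM in this assay, at which 2 of the 3 values shown sit.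

Compound 4 `CCOC(=O)C1=Cc2ccccc2OC1(OCc1cn(-c2cccc(OC)c2)nn1)C(F)(F)F` differs from compound 1 by methoxy in place of hydrogen on an aromatic carbon; cut one bond further out, the change reads phenyl to 3-methoxyphenyl. For the measured compounds named here, no measured step involves a methoxy, and the step from compound 2 to compound 3 sits on a different heteroaryl ether, so it bears on compound 4 only as a sign that a single small substituent on the pendant phenyl can move the number beyond the scatter. Compound 1 stands at a limit, so a small change would most likely leave compound 4 at a limit as well. Compound 4 is therefore expected near 120000 nM, within 40000 nM to 300000 nM. The expected step is an at least 1.2-fold lower number from compound 1 to compound 4 (0.09 log units; that floor lies within the scatter), modest at best.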

Compound 4, half-maximal inhibitory concentration: > 150000 nM
Compound 4: a limit, no number (the forecaster's own chance of this, stated with the estimate: 60%); at least 1.2-fold (0.09 log units) between middle value and limit.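

In this assay, compound 1 and compound 4 both rest at a limit and give no number, so the step between them cannot be read. The compounds shown leave open whether phenyl to 3-methoxyphenyl changes the inhibition at all, and whether any substituent on this phenyl gives a measurable value in the triazole ether series.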